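Working notes: compound 2 to compound 4

The source may hold more compounds than are shown below. What is called first, only, known or untested is meant among the compounds shown, and "the series" means these compounds.

Measured in a physicochemical assay for solubility, in phosphate buffer, with a stated time of 18 h, at pH 7.4; on this read-out higher numbers stand for higher solubility and lower numbers for lower solubility:
- compound 1 `Nc1cc2c(-n3nc(-c4ccccn4)nc3N)ncnc2cc1Cl`: 3000 nM
- compound 2 `COc1cc2ncnc(-n3nc(-c4ccccn4)nc3N)c2cc1N`: 3000 nM
- compound 3 `CCOC(=O)CNc1nc(-n2nc(-c3ccccn3)nc2N)c2cc(OC)c(OC)cc2n1`: 48000 nM

Level with compound 1, compound 2 gives 3000 nM, and together they hold the lowest of the three numbers. Compound 4 `COc1cc2ncnc(-n3nc(-c4ccccn4)nc3N)c2cc1OCCCNC(=O)OC(C)(C)C` carries 3-((tert-butoxycarbonyl)amino)propoxy in place of amino on an aromatic carbon, ortho to a methoxy group: 3-((tert-butoxycarbonyl)amino)propoxy in place of amino on an aromatic carbon. Within the data shown here, the only measured single-place step, no change at the digits printed from compound 1 to compound 2 (within the scatter), stays within the scatter, but it replaced chloro, not amino. Among the measured compounds shown here, compound 3, at 48000 nM, is higher, though no single-place step connects it to compound 2. The data therefore give no size for this change, and no step beyond the scatter is expected in this assay, in either direction, with wide uncertainty. The expected change is a 1.2-fold lower number from compound 2 to compound 4 (0.08 log units; within the scatter). For compound 4 the estimated value is 2500 nM, with an expected range of 600 nM to 12000 nM.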

Compound 4, solubility: 2000 nM
For compound 4 the middle estimate is 1.3-fold (0.10 log units) above the measured one; low and high end bracket the measured number.
By their numbers in this assay, from the lowest: compounds 4, 1 and 2 (each within the scatter of the next); then compound 3.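

In this assay, 3-((tert-butoxycarbonyl)amino)propoxy in place of amino gives a 1.5-fold lower number from compound 2 to compound 4 (0.18 log units; within the scatter) on this aromatic carbon, ortho to a methoxy group. A chain of 12 heavy atoms thus replaces a group of 1 heavy atom here with no step beyond the scatter, which the earlier step, from chloro to methoxy, could not show. Nothing at hand accounts for this result.

Still open, as far as these compounds go, is whether a free primary amine at the end of the propoxy chain, a carboxylic acid or a longer chain at this place would give a step beyond the scatter.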